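This account rests on a few compounds, and the source may have more. Where it says the series, first, only, none or still open, it means among the compounds named here.

- compound 1 `O=C(NS(=O)(=O)c1ccccc1)c1cccnc1`: 10400 nM
- compound 2 `Cc1ccc(S(=O)(=O)NC(=O)c2cccnc2)cc1`: 12300 nM

Among the compounds with values here, both values come from a functional assay on HepG2 cells (Homo sapiens) for antiproliferative activity, read by colorimetric assay and MTT assay, with a stated time of 48 h (on this read-out higher numbers stand for weaker inhibition and lower numbers for stronger inhibition), and are the only numbers available so far. Within the data shown here, compound 1 and compound 2 lie within the scatter of each other, so compound 1 cannot be ranked against its one neighbour.

Compound 3 `O=C(NS(=O)(=O)c1ccccc1)c1ccccn1` has not yet been measured. It has the same atoms as compound 1, joined differently: pyridin-2-yl in place of pyridin-3-yl on a carbonyl carbon describes the change, with pyridin-2-yl in place of pyridin-3-yl on a carbonyl carbon.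

Among the measured compounds shown here, only one measured step exists, and it bears on this change only indirectly. That step, a 1.2-fold higher number from compound 1 to compound 2 (0.07 log units; within the scatter) and within the scatter, is methyl in place of hydrogen on an aromatic carbon. For the measured compounds named here, no measured pair exchanges one pyridinyl group for another, so the data point in neither direction. The expectation in this assay is therefore no step beyond the scatter, though this rests on thin evidence. The estimated step is a 1.1-fold higher number from compound 1 to compound 3 (0.02 log units; within the scatter) and carries a wide margin. Compound 3 is expected at 11000 nM with an estimated range from 4500 nM to 27000 nM in this measurement.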

Compound 3, half-maximal inhibitory concentration: 9900 nM
Compound 3: middle estimate off by 1.1-fold (0.05 log units), on the high side; measured number inside the range.
By their numbers in this assay, from the lowest: compounds 3, 1 and 2 (each within the scatter of the next).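

Within the data shown here, the exchange of pyridin-3-yl for pyridin-2-yl on a carbonyl carbon gives, in this assay, a 1.1-fold lower number from compound 1 to compound 3 (0.02 log units; within the scatter) and is the first measured change at this place, where the other neighbour of that carbon is the amide-type nitrogen. Moving the attachment point of the pyridinyl group therefore leaves no readable difference here, and the only other step shown, methyl in place of hydrogen on an aromatic carbon, is also within the scatter at a 1.2-fold higher number from compound 1 to compound 2 (0.07 log units; within the scatter) in this read-out. No measurement accompanies the result that could explain why compound 1 and compound 3 read alike.

The compounds shown leave open whether any group on this carbonyl carbon can shift the number beyond the scatter, since each of them carries a pyridinyl group there. Pyridin-4-yl would complete the set of attachment points, while a pyridinyl group bearing an amine or a carboxylic acid would test whether a substituent on that ring matters more than the attachment point.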